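The compounds below may be only part of what the source reports. "The series", "measured", "known", "first", "only" and "open" are said of these compounds alone.

Working notes on the series. In a functional assay on HGC-27 cells (Homo sapiens) for inhibition, read by MTT assay, with a stated time of 72 h (a lower number here means a stronger inhibitor, a higher number a weaker inhibitor), compound 1 (`Cc1cc(N2CC[C@@H](C)[C@@H](N(C)c3ncnc4[nH]ccc34)C2)n2nc(SCc3nc4ccccc4[nH]3)nc2n1`) gives > 100000 nM, and this is a limit of the assay, not a number. Going by the values given here, compound 2 (`Cc1cc(N2CC[C@@H](C)[C@@H](N(C)c3ncnc4[nH]ccc34)C2)n2nc(SCc3ccc(F)cc3)nc2n1`) gives 26000 nM, the only true number so far. Among the compounds with values here, the single measured step, an at least 3.8-fold lower number from compound 1 to compound 2 (0.58 log units; beyond the scatter), puts 4-fluorophenyl in place of 1H-benzimidazol-2-yl, so the group on the sulfur chain can shift this assay. Within the data shown here, that step replaces a whole aromatic group and offers only indirect guidance here, and no measured step covers a chloro group.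

Compound 3 (`Cc1cc(N2CC[C@@H](C)[C@@H](N(C)c3ncnc4[nH]ccc34)C2)n2nc(SCc3ccc(F)c(Cl)c3)nc2n1`) carries chloro in place of hydrogen on an aromatic carbon, going from 4-fluorobenzyl to 3-chloro-4-fluorobenzyl, with the chloro ortho to a fluoro group. This is a smaller change than the step from the benzimidazole, so only a small move towards a lower number is expected, a 1.6-fold lower number from compound 2 to compound 3 (0.21 log units; within the scatter). For compound 3 the estimated value is 16000 nM, with an expected range of 6000 nM to 45000 nM.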

Compound 3, half-maximal inhibitory concentration: > 100000 nM
Compound 3: no number, only a limit; the forecaster's own chance of this, stated with the estimate: 10%; at least 6.2-fold (0.79 log units) between middle value and limit.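

In this assay compound 3 gives > 100000 nM, and this is a limit of the assay, not a number. Adding chloro to the 4-fluorobenzyl group gives an at least 3.8-fold higher number from compound 2 to compound 3 (0.58 log units; beyond the scatter), so a single chloro on this ring, ortho to a fluoro group, can shift the number, a change much smaller than the replacement of a whole aromatic group in the earlier step. The step between compound 1 and compound 3 cannot be read, and compound 2 remains the only compound with a true number: the limit of > 100000 nM in this assay, at which 2 of the 3 values shown sit.

On these data alone, whether this shift is specific to chloro or would also follow from a methoxy group or an amine on the same aromatic carbon remains open. Also open, as far as these compounds go, is whether chloro has the same effect on a benzyl group without the fluoro group.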